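A few compounds are considered here, and "the series" means these few. Any claim that something is new, unique, unknown or untested is made for them only; others in the source may bear on it.

Compound 1 `CN(C)CCCNc1ccc(/N=N/c2ccc([N+](=O)[O-])cc2)cc1` was examined for cytotoxicity in an ADME assay on MDBK cells (Bos taurus) for cytotoxicity, read by MTT assay, with a stated time of 96 h; a lower number here means that less compound is tolerated, a higher number that more compound is tolerated. In this assay compound 1 gives > 100000 nM, which is a limit of the assay and not a measured number. Compound 2 `O=[N+]([O-])c1cccc(/N=N/Nc2cccc([N+](=O)[O-])c2)c1` was tested in the same way, and in this assay compound 2 gives > 100000 nM, again a limit rather than a number. Among the measured compounds shown here, compound 1 therefore stands at the limit of > 100000 nM in this assay, at which 2 of the 2 values shown sit; no measured compound sits anywhere else, so no ordering among the two can be drawn from these data.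

Compound 3 `CN(C)CCCNc1ccc(/N=N/c2ccccc2)cc1` has not yet been measured in this assay. It differs from compound 1 by hydrogen in place of nitro on an aromatic carbon. For the measured compounds named here, no step between two measured compounds is available to calibrate this change. Given that both measured compounds rest at the limit, the step expected from compound 1 to compound 3 in this assay, a number no higher from compound 1 to compound 3 (the limit leaves the size open), is none beyond the usual scatter. Compound 3 is accordingly expected to give about 100000 nM in this assay, with a likely range from 50000 nM to 200000 nM, and most probably the assay will again report only a limit for compound 3.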

Compound 3, half-maximal cytotoxic concentration: 58000 nM
The estimate for compound 3 lay 1.7-fold (0.24 log units) above the measured number; low and high end bracket the measured number.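

Among the compounds shown here, compound 3 gives the first value in this assay that is a number and not a limit, so the exchange of nitro for hydrogen at this position, para to a large group, now has a readable end point. Hydrogen in place of nitro on this aromatic carbon amounts to an at least 1.7-fold lower number from compound 1 to compound 3 (0.23 log units; that floor lies within the scatter), which leaves room both for a change no greater than scatter and for a much larger one. Only this floor can be stated, because compound 1 rests at a limit of the assay and not at a measured number: the limit of > 100000 nM in this assay, at which 2 of the 3 values shown sit.

Going by these compounds, whether another group on this aromatic carbon, such as an amine, a methoxy group or a chlorine atom, would give a number like compound 3 or a limit like compound 1 remains open. For the compounds shown here, also open is how a longer chain in place of the one carrying the dimethylamino group would read in this assay, with nitro or with hydrogen on the aromatic carbon; compound 2 differs from compound 1 and compound 3 in more than one place and cannot settle either question.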